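Phenoxy sugar ethers: cytotoxicity on A549 cells

A few compounds are considered here, and "the series" means these few. Any claim that something is new, unique, unknown or untested is made for them only; others in the source may bear on it.

Measured so far in a functional assay on A549 cells (Homo sapiens) for cytotoxicity, read by MTT assay, with a stated time of 48 h; on this read-out higher numbers stand for an effect only at larger amounts of compound and lower numbers for an effect already at smaller amounts:

compound 1, `CO[C@@H]1O[C@H](COc2cccc(C(C)C)c2)[C@@H](O)[C@H](O)[C@H]1Oc1ccc(OC2CCCCC2)cc1`: 41000 nM
compound 2, `CO[C@H]1O[C@H](COc2ccc(OC3CCCCC3)cc2)[C@@H](O)[C@H](O)[C@H]1Oc1ccc(OC2CCCCC2)cc1`: 18000 nM
compound 3, `CO[C@H]1O[C@H](COc2ccc(-c3ccccc3)cc2)[C@@H](O)[C@H](O)[C@H]1Oc1ccccc1`: 36000 nM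

All three compounds share the same sugar core and differ in the two aryl ether groups. On the numbers shown, compound 3 holds the second highest value of the three in this assay. Its nearest neighbour is compound 1, whose value lies within the usual scatter of compound 3, and its furthest is compound 2, whose value also lies within the scatter. Among the measured compounds shown here, no order among the three can therefore be read from compound 3 alone, and no single-point step between any two measured compounds is available.

Compound 4, `CO[C@H]1O[C@H](COc2ccc(-c3ccccc3)cc2)[C@@H](O)[C@H](O)[C@H]1Oc1cccc(C(C)C)c1`, keeps the biphenyl ether of compound 3 and differs from it only at the phenoxy group: isopropyl in place of hydrogen on an aromatic carbon. The change is small and brings in no ring, no donor and no acceptor. For the measured compounds named here, with no measured pair showing what an isopropyl adds here, the step from compound 3 is expected to be a 1.2-fold lower number from compound 3 to compound 4 (0.08 log units; within the scatter), that is, nothing beyond the scatter in either direction. Compound 4 is accordingly estimated at 30000 nM in this assay, with a range from 12000 nM to 75000 nM.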

Compound 4, half-maximal effective concentration: 32000 nM
For compound 4 the middle estimate is 1.1-fold (0.03 log units) below the measured one, within the range that was stated.
By their numbers in this assay, from the lowest: compounds 2, 4, 3 and 1 (each within the scatter of the next, the first and the last beyond it).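

Among the compounds shown here, this is the first step that can be read at a single place. In this assay isopropyl in place of hydrogen on the phenoxy group gives a 1.1-fold lower number from compound 3 to compound 4 (0.05 log units; within the scatter) and so, at this position on a six-membered aromatic ring of carbon only, meta to a large group, the change stays within the scatter. This holds for this one pair, with the biphenyl ether unchanged, and no measurement from outside this assay bears on the result.

For the compounds shown here, whether an amine, a carboxylic acid or a longer chain at this position would give a step beyond the scatter remains open, since isopropyl is the only group with a readable step here. All other pairs among the compounds shown differ in more than one place, so the separate contributions of the biphenyl ether, the cyclohexyloxy groups and the isopropyl on the other aryl ether of compound 1 cannot be read, and it stays unknown whether this step would carry over to a partner other than the biphenyl ether.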